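A Methoxy Group on a Compound at the Limit

This account rests on a few compounds, and the source may have more. Where it says the series, first, only, none or still open, it means among the compounds named here.

In an ADME assay on the whole organism (Rattus norvegicus, strain Lewis) for metabolic stability, read by LC-MS, with a stated time of 72 h, at a dose of 2 mg/kg by the oral route (a higher number here means that the compound lasts longer, a lower number that the compound disappears faster), compound 1 (`N[C@]1(CO)CC[C@H](c2ccc3c(c2)CC[C@@H](CCc2ccccc2)C3)C1`) gives > 75 h as a limit and not as a number. Its stereoisomer compound 2 (`N[C@]1(CO)CC[C@H](c2ccc3c(c2)CC[C@H](CCc2ccccc2)C3)C1`) gives > 75 h as a limit too. Compound 1 thus stands at the limit of > 75 h in this assay, at which 2 of the 3 values shown sit, and has no exact figure of its own.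

Compound 4 (`COc1cccc(CC[C@@H]2CCc3cc([C@H]4CC[C@](N)(CO)C4)ccc3C2)c1`) carries one change from compound 1 (methoxy in place of hydrogen on an aromatic carbon), namely phenyl to 3-methoxyphenyl. Among the measured compounds shown here, the only measured step is a step that the two limits leave unreadable from compound 1 to compound 2 and it offers no size to build on. It concerns the fact that compounds 1 and 2 differ only in the configuration as drawn and does not touch the methoxy group.

For the measured compounds named here, the nearest guide is compound 3 (`COc1ccc(CC2CCc3cc([C@H]4CC[C@](N)(CO)C4)ccc3C2)cc1`), which also carries a methoxy group and gives 64 h in this assay as a true number, though no single step joins it to compound 1. Going by the values given here, with compound 3 at 64 h as the only such reading, the change is expected to stay within the usual scatter, with no firm direction. Compound 4 may well reach the limit too.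

The expected step is an at least 1.0-fold lower number from compound 1 to compound 4 (0.02 log units; that floor lies within the scatter) and it remains an estimate against a limit. For compound 4 the estimated half-life is 70 h with an expected range from 40 h to 120 h in this assay's usual terms.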

Compound 4, half-life: 31 h
The estimate for compound 4 lay 2.3-fold (0.35 log units) above the measured number; measured number outside the range, below it.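

Placing methoxy in place of hydrogen on an aromatic carbon, meta to a large group, gives an at least 2.4-fold lower number from compound 1 to compound 4 (0.38 log units; beyond the scatter) in this assay. This is the first step among these compounds with a readable direction, as the only earlier step joined two stereoisomers and could not be read, so the outer phenyl ring of compound 1 now appears as a place where one added group can move the half-life beyond the scatter. The size of the step is only a floor, because compound 1 holds a limit and no exact figure of its own: the limit of > 75 h in this assay, at which 2 of the 4 values shown sit.

The compounds shown leave open whether a fluorine atom, a hydroxyl group or an ethoxy group on the same aromatic carbon would give a step in the same direction, and whether a methoxy group there would lower the half-life of the stereoisomer compound 2 in the same way. They also give no cause for the lower number, and they do not tell whether the methoxy group itself or only its place on the ring is what counts.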